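From Ethyl to Isopropoxy on a Bile Acid Receptor Agonist

This account rests on a few compounds, and the source may have more. Where it says the series, first, only, none or still open, it means among the compounds named here.

Of the compounds shown here, two sharing one core have been measured in a functional assay for agonist activity at Bile acid receptor (Homo sapiens), read by FRET; a higher number here means that more compound is needed for the effect, a lower number that less compound is needed. Compound 1, `CC(C)c1onc(-c2c(Cl)cccc2Cl)c1COc1ccc(-c2ccc3nc(C(=O)O)nnc3c2)cc1`, gives 360 nM in this assay. Compound 2, `CCc1cc(C(=O)O)nc2ccc(-c3ccc(OCc4c(-c5c(Cl)cccc5Cl)noc4C(C)C)cc3)cc12`, gives 75 nM in this assay, the lowest of the two numbers, and its gap to compound 1 lies beyond the usual scatter. Compound 3, `CC(C)Oc1cc(C(=O)O)nc2ccc(-c3ccc(OCc4c(-c5c(Cl)cccc5Cl)noc4C(C)C)cc3)cc12`, has not yet been measured in this assay. It differs from compound 2 in one place: isopropoxy in place of ethyl on an aromatic carbon. For the measured compounds named here, no measured pair in this set shows the same change, so there is nothing to lean on for its size or direction. Going by the values given here, the entering group brings one hydrogen-bond acceptor where the leaving group carries none, but nothing among the measured compounds tells how this assay responds to that. The expected step from compound 2 to compound 3 is therefore a 1.2-fold higher number from compound 2 to compound 3 (0.08 log units; within the scatter), small and of uncertain direction. Compound 3 is expected to give about 90 nM in this assay, within a range from 30 nM to 300 nM.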

Compound 3, half-maximal effective concentration: 40 nM
Compound 3: the middle estimate sits 2.3-fold (0.35 log units) above what was measured, within the range that was stated.
By their numbers in this assay, from the lowest: compounds 3 and 2 (each within the scatter of the next); then compound 1.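

On the aromatic carbon opposite the ring nitrogen, isopropoxy in place of ethyl gives a 1.9-fold lower number from compound 2 to compound 3 (0.27 log units; within the scatter) in this assay, the first step read at this place, since compound 1 differs from the other two in more than one place. The step shows that this position accepts a group of 4 heavy atoms with 1 hydrogen-bond acceptor in place of the 2 carbon atoms of ethyl, and that in this assay compound 3 stays level with compound 2 within the usual scatter. No measurement comes with the result that would say what lies behind this step, so it stands as an observation only.

What the compounds shown leave open is whether the oxygen or the branched chain shapes the reading here, and a methoxy or an n-propyl group on the same aromatic carbon would begin to separate the two. Going by these compounds, how far this position keeps accepting change is also open, since a single step says nothing about an amine, a carboxylic acid or a longer alkoxy chain in the same place.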